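The source may report more compounds than this note shows. Statements on the series, on what has been measured and on what is new or still open speak of the compounds shown alone.

In a functional assay on L1210 cells (Mus musculus) for inhibition, read by MTT assay, with a stated time of 72 h (a lower number here means a stronger inhibitor, a higher number a weaker inhibitor), compound 3 `COc1cc(NC(C)CCCNC(=O)NNC(=O)Nc2ccc(Br)cc2)c2ncccc2c1` gives 51000 nM as the highest of three numbers, against compound 1 `COc1cc(NC(C)CCCNC(=O)Nc2cccc(F)c2)c2ncccc2c1` at 19000 nM and compound 2 `COc1cc(NC(C)CCCNC(=O)Nc2ccc(F)cc2)c2ncccc2c1` at 18000 nM on the same read-out. Compound 4 `COc1cc(NC(C)CCCNC(=O)Nc2ccc(Cl)cc2)c2ncccc2c1` has 4-chlorophenyl in place of ((4-bromophenyl)carbamoyl)amino on an amide-type nitrogen. Two measured steps make the reverse kind of exchange with a fluorophenyl group: a 2.7-fold higher number from compound 1 to compound 3 (0.43 log units; beyond the scatter) and a 2.8-fold higher number from compound 2 to compound 3 (0.45 log units; beyond the scatter) are both modest, while a 1.1-fold lower number from compound 1 to compound 2 (0.02 log units; within the scatter) stays within the scatter. Going by the values given here, a modest step to a lower number is therefore expected in this assay of about that size, although no chlorophenyl compound has been measured. The expected step is a 2.8-fold lower number from compound 3 to compound 4 (0.45 log units; beyond the scatter) in size. Compound 4 is estimated at 18000 nM with a range from 10000 nM to 32000 nM as the expected span.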

Compound 4, half-maximal inhibitory concentration: 19000 nM
For compound 4 the middle estimate is 1.1-fold (0.02 log units) below the measured one; low and high end bracket the measured number.
By their numbers in this assay, from the lowest: compounds 2, 1 and 4 (each within the scatter of the next); then compound 3.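

In this assay, chloro in place of fluoro on an aromatic carbon stays within the scatter: a 1.1-fold higher number from compound 2 to compound 4 (0.02 log units; within the scatter). The same holds for 4-chlorophenyl in place of 3-fluorophenyl on this amide-type nitrogen, with no change at the digits printed from compound 1 to compound 4 (within the scatter). With a 2.7-fold lower number from compound 3 to compound 4 (0.43 log units; beyond the scatter), compound 3 has the highest number of the four, its step to each of the others lying beyond the scatter, and no evidence here accounts for any of these results.

Still open, from the compounds shown here alone, is how an amine or a carboxylic acid on the phenyl ring would read in this assay. Going by these compounds, a longer chain in place of the phenyl ring on this nitrogen also remains open.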